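Vero cytotoxicity of a chalcone amide series: difluorophenyl analogue

The source may hold more compounds than are shown below. What is called first, only, known or untested is meant among the compounds shown, and "the series" means these compounds.

Compound 3 `CCOc1ccc(C(=O)/C=C/c2ccc(C(=O)Nc3cccc(-c4cc(C(=O)OC)no4)c3)cc2)cc1` gives only a limit in an ADME assay on Vero cells (Chlorocebus sabaeus) for cytotoxicity, read by MTT assay, with a stated time of 72 h (on this read-out higher numbers stand for lower toxicity in this test and lower numbers for higher toxicity in this test), namely > 40 ug/mL. Compound 1 `COC(=O)c1cc(-c2cccc(NC(=O)c3ccc(/C=C/C(=O)c4ccccc4)cc3)c2)on1` also gives only a limit in this assay, > 50 ug/mL. Compound 2 `COC(=O)c1cc(-c2cccc(NC(=O)c3ccc(/C=C/C(=O)c4cccc([N+](=O)[O-])c4)cc3)c2)on1` likewise gives only a limit, > 40 ug/mL. Every measured value is thus a limit: the limit of > 40 ug/mL in this assay, at which 2 of the 3 values shown sit, and (the limit of > 50 ug/mL in this assay, at which 1 of the 3 values shown sits). The steps a step that the two limits leave unreadable from compound 1 to compound 2, a step that the two limits leave unreadable from compound 1 to compound 3 and a step that the two limits leave unreadable from compound 2 to compound 3 cannot be read in size.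

Compound 4 `COC(=O)c1cc(-c2cccc(NC(=O)c3ccc(/C=C/C(=O)c4cc(F)ccc4F)cc3)c2)on1` differs from compound 3 by 2,5-difluorophenyl in place of 4-ethoxyphenyl on a carbonyl carbon; the 4-ethoxyphenyl leaves, the 2,5-difluorophenyl enters on the carbonyl carbon. For the measured compounds named here, no measured step bears on this change, and nothing points away from a limit. For compound 4 the expected step is a step that the limit leaves unreadable from compound 3 to compound 4, no more than scatter, with the value expected again at a limit, estimated as 60 ug/mL in this assay.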

Compound 4, half-maximal cytotoxic concentration: > 40 ug/mL
Compound 4: no number, only a limit; the forecaster's own chance of this, stated with the estimate: 75%; the middle value lies beyond the limit too.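

For the compounds shown here, compound 4 gives only a limit, and no step to it from compound 1, compound 2 or compound 3 can be read in this assay. The compounds shown leave open where the half-maximal cytotoxic concentration of any of the four lies, and whether the groups on the carbonyl carbon change it.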